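Aryl change from compound 3 to compound 4

This account rests on a few compounds, and the source may have more. Where it says the series, first, only, none or still open, it means among the compounds named here.

In a functional assay on SW480 cells (Homo sapiens) for antiproliferative activity, read by sulforhodamine B assay, with a stated time of 48 h (a lower number here means a stronger inhibitor, a higher number a weaker inhibitor), compound 1 `COc1ccc(/C=C/C(=O)C(=Cc2ccc(O)c(F)c2)C(=O)/C=C/c2ccc(OC)cc2OC)c(OC)c1` gives 3350 nM, compound 2 `COc1ccc(/C=C/C(=O)C(=Cc2cc(Br)c(O)c(OC)c2)C(=O)/C=C/c2ccc(OC)cc2OC)c(OC)c1` gives 1480 nM and compound 3 `COc1ccc(/C=C/C(=O)C(=Cc2cc(OC)c(O)c(OC)c2)C(=O)/C=C/c2ccc(OC)cc2OC)c(OC)c1` gives 850 nM. Two compounds share the low end of these numbers: a 1.7-fold lower number from compound 2 to compound 3 (0.24 log units; within the scatter). The third stands clear: a 3.9-fold lower number from compound 1 to compound 3 (0.60 log units; beyond the scatter). Compound 4 `COc1ccc(/C=C/C(=O)C(=Cc2ccc(OC)c(O)c2)C(=O)/C=C/c2ccc(OC)cc2OC)c(OC)c1` carries 3-hydroxy-4-methoxyphenyl in place of 4-hydroxy-3,5-dimethoxyphenyl on a double-bonded chain carbon bound to a double-bonded chain carbon, with 3-hydroxy-4-methoxyphenyl in place of 4-hydroxy-3,5-dimethoxyphenyl. Within the data shown here, the steps that bear on this change sit at the same place, and both are modest: a 2.3-fold lower number from compound 1 to compound 2 (0.35 log units; beyond the scatter), and the step to compound 3 above. Compound 1, which also lacks the 4-hydroxy-3,5-dimethoxyphenyl group, gives 3350 nM, so a move to a higher number in this assay is expected. The estimated step is a 2.1-fold higher number from compound 3 to compound 4 (0.33 log units; beyond the scatter). Compound 4 is estimated at 1800 nM, with an expected range of 700 nM to 4500 nM.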

Compound 4, half-maximal inhibitory concentration: 1370 nM
Estimate against measurement, compound 4: 1.3-fold (0.12 log units) above; the range from low to high includes it.
By their numbers in this assay, from the lowest: compounds 3, 4 and 2 (each within the scatter of the next); then compound 1.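

At the double-bonded chain carbon bound to a double-bonded chain carbon, 3-hydroxy-4-methoxyphenyl cannot be told apart from the two larger aryl groups in this assay: a 1.6-fold higher number from compound 3 to compound 4 (0.21 log units; within the scatter), and a 1.1-fold lower number from compound 2 to compound 4 (0.03 log units; within the scatter). It stands clear only of the 3-fluoro-4-hydroxyphenyl group, with a 2.4-fold lower number from compound 1 to compound 4 (0.39 log units; beyond the scatter). Among these four compounds, therefore, the aryl groups carrying a methoxy group stay together, and only the fluoro compound, which has no methoxy group, lies apart; no evidence bears on the reason. Still open, on these data alone, is how an amine or a carboxylic acid on this aryl group would read in this assay.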